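This account rests on a few compounds, and the source may have more. Where it says the series, first, only, none or still open, it means among the compounds named here.

Of the compounds shown here, three built on a shared core have been tested in an assay on CHO cells for displacement of a labelled ligand from adenosine receptor A1 (Homo sapiens), read by scintillation counting, with a stated time of 90 min; a higher number here means a weaker inhibitor, a lower number a stronger inhibitor. Compound 1 `COc1ccccc1CNc1nc(N)c2nc(-c3cccs3)sc2n1` gives 17.3 nM in this assay. Compound 2 `Cc1ccc(-c2nc3c(N)nc(NCc4cccs4)nc3s2)o1` gives 71 nM. Compound 3 `Nc1nc(NCc2cnccn2)nc2sc(-c3ccco3)nc12` gives 25 nM, which places it second highest of the three numbers: its gap to compound 1 lies within the usual scatter, while its gap to compound 2 lies beyond it, with compound 2 showing the higher number.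

Compound 4 `Nc1nc(NCc2ccccn2)nc2sc(-c3ccco3)nc12` has not yet been measured. It differs from compound 3 in one place: pyridin-2-yl in place of pyrazin-2-yl on a saturated chain carbon bound to a nitrogen on an aromatic ring. For the measured compounds named here, no step between measured compounds matches this change, so the expectation rests on compound 3 alone. Both groups hold six heavy atoms in one six-membered aromatic ring, and the swap trades two ring nitrogens for one. The step is expected to be small, a 1.7-fold lower number from compound 3 to compound 4 (0.22 log units; within the scatter), leaning toward a lower number but not clearly beyond the scatter. Compound 4 is therefore expected to give about 15 nM in this assay, within a range from 6 nM to 40 nM.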

Compound 4, inhibition constant: 28 nM
For compound 4 the middle estimate is 1.9-fold (0.27 log units) below the measured one; the range from low to high includes it.
By their numbers in this assay, from the lowest: compounds 1, 3 and 4 (each within the scatter of the next); then compound 2.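

In this assay, pyridin-2-yl in place of pyrazin-2-yl on a saturated chain carbon bound to a nitrogen on an aromatic ring gives a 1.1-fold higher number from compound 3 to compound 4 (0.05 log units; within the scatter) and so no real change. For the compounds shown here, this is the first comparison here in which only one place differs, and it shows that at this position the two rings cannot be told apart in this assay, even though the entering ring holds one nitrogen fewer. No measured information is available that would explain this result.

On these data alone, both rings are six-membered aromatic rings, so it remains open whether a group of another kind at this position, such as a plain phenyl ring or a morpholine, would shift the number beyond the scatter. As far as these compounds go, it also remains open whether the same swap would give so small a step on a compound carrying a different group elsewhere on the shared core.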